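The source may report more compounds than this note shows. Statements on the series, on what has been measured and on what is new or still open speak of the compounds shown alone.

Compound 3 `COc1ccc(CNCCCNS(=O)(=O)c2cc(C(F)(F)F)cc(C(F)(F)F)c2)cc1OC` gives 6400 nM in a functional assay on ASPC1 cells (Homo sapiens) for inhibition, read by MTT assay, with a stated time of 72 h (a lower number here means a stronger inhibitor of growth, a higher number a weaker inhibitor of growth), the second highest of the three numbers: compound 2 `O=S(=O)(NCCNCc1ccc(-c2ccccc2)cc1)c1cc(C(F)(F)F)cc(C(F)(F)F)c1` gives 2800 nM and compound 1 `O=S(=O)(NCCCNCc1cccc2ccccc12)c1cc(C(F)(F)F)cc(C(F)(F)F)c1` gives 21000 nM. Among the measured compounds shown here, the one step measured on the shared core, a 3.3-fold lower number from compound 1 to compound 3 (0.52 log units; beyond the scatter), exchanged naphthalen-1-yl for 3,4-dimethoxyphenyl. Compound 4 `COc1cccc(CNCCCNS(=O)(=O)c2cc(C(F)(F)F)cc(C(F)(F)F)c2)c1` differs from compound 3 by a smaller change, (hydrogen in place of methoxy on an aromatic carbon). For the measured compounds named here, no measured step removes a single methoxy, so the only guide is that the larger swap of the aryl group moved the number by a modest amount; loss of one methoxy is expected to move it less in this assay, in either direction or not beyond the scatter. Compound 4 is estimated at 8000 nM, with a range of 3000 nM to 22000 nM, an expected step of a 1.3-fold higher number from compound 3 to compound 4 (0.10 log units; within the scatter).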

Compound 4, concentration for 50% growth inhibition: 3800 nM
Estimate against measurement, compound 4: 2.1-fold (0.32 log units) above; measured number inside the range.
By their numbers in this assay, from the lowest: compounds 2, 4 and 3 (each within the scatter of the next, the first and the last beyond it); then compound 1.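

Hydrogen in place of methoxy, taking 3,4-dimethoxyphenyl to 3-methoxyphenyl, gives in this assay a 1.7-fold lower number from compound 3 to compound 4 (0.23 log units; within the scatter) and so leaves this position without a shift beyond the scatter. With a 5.5-fold lower number from compound 1 to compound 4 (0.74 log units; beyond the scatter) as a second aryl step, 3-methoxyphenyl joins 3,4-dimethoxyphenyl in standing apart from naphthalen-1-yl beyond the scatter. Nothing at hand bears on the cause of either step.

Open remain whether the other methoxy can also give way to hydrogen or to a hydroxyl, and how a longer chain would read with 3-methoxybenzyl.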